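Swapping a Methoxyphenyl for a Carboxyphenyl

The source may hold more compounds than are shown below. What is called first, only, known or untested is meant among the compounds shown, and "the series" means these compounds.

Compound 1 `COc1cccc(C2(CNC(=O)Nc3c(C(C)C)cccc3C(C)C)CCCC2)c1` is the starting point of this step. Among the compounds with values here, in an assay on microsomes for inhibition of acyl-CoA:cholesterol acyltransferase (Oryctolagus cuniculus) (on this read-out higher numbers stand for weaker inhibition and lower numbers for stronger inhibition), compound 1 gives 13 nM, the lowest of the three numbers measured so far. Compound 2 `CC(C)c1cccc(C(C)C)c1NC(=O)NCC1(c2ccc(C(F)(F)F)cc2)CCCC1` gives 66 nM and compound 3 `CC(C)c1cccc(C(C)C)c1NC(=O)NCC1(c2cccc([N+](=O)[O-])c2)CCCC1` gives 51 nM in this assay. Both are replacements of the 3-methoxyphenyl of compound 1: a 5.1-fold higher number from compound 1 to compound 2 (0.71 log units; beyond the scatter) and a 3.9-fold higher number from compound 1 to compound 3 (0.59 log units; beyond the scatter), while a 1.3-fold lower number from compound 2 to compound 3 (0.11 log units; within the scatter). Compound 4 `CC(C)c1cccc(C(C)C)c1NC(=O)NCC1(c2ccc(C(=O)O)cc2)CCCC1` is not yet measured; it differs from compound 1 by 4-carboxyphenyl in place of 3-methoxyphenyl on a saturated ring carbon. The two measured replacements of the 3-methoxyphenyl both weakened inhibition modestly. For compound 4 a modest rise is therefore expected, a 6.9-fold higher number from compound 1 to compound 4 (0.84 log units; beyond the scatter). Compound 4 is thus estimated at 90 nM, with a range from 25 nM to 400 nM.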

Compound 4, half-maximal inhibitory concentration: 3100 nM
The estimate for compound 4 lay 34-fold (1.54 log units) below the measured number; measured number outside the range, above it.
By their numbers in this assay, from the lowest: compound 1; then compounds 3 and 2 (each within the scatter of the next); then compound 4.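

Unlike the modest earlier replacements, the 4-carboxyphenyl shows that a single change at this saturated ring carbon can nearly abolish inhibition, with a 240-fold higher number from compound 1 to compound 4 (2.38 log units; beyond the scatter) and a 61-fold higher number from compound 3 to compound 4 (1.78 log units; beyond the scatter) as large steps. The closest comparison is a 47-fold higher number from compound 2 to compound 4 (1.67 log units; beyond the scatter). In this pair, only carboxy replaces trifluoromethyl on an aromatic carbon. Nothing available explains why this step is so large.

As far as these compounds go, whether the methyl ester of the acid or an amine in the same place would behave like compound 4 remains open.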